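The compounds below may be only part of what the source reports. "The series", "measured", "known", "first", "only" and "open" are said of these compounds alone.

Measured compounds:
compound 1, `CCc1ccccc1OS(=O)(=O)c1ccc(NC(=O)NCCCCl)cc1`: 15000 nM
compound 2, `O=C(NCCCCl)Nc1ccc(S(=O)(=O)Oc2ccc(O)cc2)cc1`: 51000 nM
compound 3, `Cc1ccccc1NS(=O)(=O)c1ccc(NC(=O)NCCCCl)cc1`: > 200000 nM

In a functional assay on MCF7 cells (Homo sapiens) for cytotoxicity, read by sulforhodamine B assay, with a stated time of 48 h (on this read-out higher numbers stand for weaker inhibition and lower numbers for stronger inhibition), compound 2 gives the highest of the two numbers that were reported as numbers. Its nearest neighbour is compound 1, and the change from the one to the other is a 3.4-fold higher number from compound 1 to compound 2 (0.53 log units; beyond the scatter), a 4-hydroxyphenyl in place of a 2-ethylphenyl on the oxygen. Compound 3 reaches only a limit of this assay. One of the three values sits at the limit of > 200000 nM in this assay, at which 1 of the 3 values shown sits, and the corresponding step, an at least 3.9-fold higher number from compound 2 to compound 3 (0.59 log units; beyond the scatter), follows a (2-methylphenyl)amino in place of the 4-hydroxyphenoxy on the sulfonyl sulfur.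

Compound 4, `CCNC(=O)Nc1ccc(S(=O)(=O)Oc2ccc(O)cc2)cc1`, differs from compound 2 by hydrogen in place of chloromethyl on a saturated chain carbon, two bonds along the chain from an amide-type nitrogen. Neither of the measured steps touches the (3-chloropropyl)amino side of the urea: one alters the aryl on the oxygen, the other the group on the sulfonyl sulfur. Among the measured compounds shown here, there is thus no measured step in this set that bears directly on the change, and the expectation rests on the observation that compound 2 already stands at the weaker end of the reported numbers while compound 3 sits at a limit.

Compound 4 is therefore expected to lose further activity in this assay, with an estimated step of a 2.4-fold higher number from compound 2 to compound 4 (0.37 log units; beyond the scatter). The estimate for compound 4 is 120000 nM, with a range from 30000 nM to 400000 nM, and a fair chance that this assay will report only a limit.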

Compound 4, half-maximal inhibitory concentration: 8000 nM
Beside the measured number, compound 4's estimate is 15-fold (1.18 log units) above it, outside the stated range (below it).
By their numbers in this assay, from the lowest: compounds 4 and 1 (each within the scatter of the next); then compound 2. At a limit, above all of these: compound 3.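

In this assay, cutting (3-chloropropyl)amino back to ethylamino, with the 4-hydroxyphenyl on the oxygen kept, gives a 6.4-fold lower number from compound 2 to compound 4 (0.80 log units; beyond the scatter), which on this read-out means stronger inhibition. Among the compounds shown here, the chlorine-bearing end of the chain is therefore not required for the activity of this pair, and in this pair its loss goes with a gain; the earlier steps changed only the aryl on the oxygen and the group on the sulfonyl sulfur, whereas this one shows that the other side of the urea can also move the number. Nothing measured in this set gives a reason for the size or the direction of this step.

The compounds shown leave open whether the gain comes from losing the chlorine or from shortening the chain, since the two change together here; a propyl chain without chlorine, or a 3-hydroxypropyl chain, would separate them. Going by these compounds, it also remains open whether the same change would hold with the 2-ethylphenyl of compound 1 on the oxygen.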